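Replacing the 3-fluorophenyl group of compound 3

The source may hold more compounds than are shown below. What is called first, only, known or untested is meant among the compounds shown, and "the series" means these compounds.

Measured in a functional assay on HepG2 cells (Homo sapiens) for cytotoxicity, read by spectrophotometry, with a stated time of 72 h; a lower number here means a stronger inhibitor, a higher number a weaker inhibitor:
- compound 1 `COc1ccc(-n2c(-c3cc(OC)c(OC)c(OC)c3)cccc2=O)cc1O`: 1220 nM
- compound 2 `COc1ccc(-n2c(-c3cc(OC)c(OC)c(OC)c3)cccc2=O)cc1`: 5740 nM
- compound 3 `COc1cc(-c2cccc(=O)n2-c2cccc(F)c2)cc(OC)c1OC`: 73 nM

Of these three, compound 3 stands lowest (73 nM), and its steps to both others lie beyond the scatter. Compound 4 `COc1cc(-c2cccc(=O)n2-c2ccncc2)cc(OC)c1OC` has not been measured. It differs from compound 3 in one place (pyridin-4-yl in place of 3-fluorophenyl on an aromatic nitrogen), with pyridin-4-yl in place of 3-fluorophenyl on an aromatic nitrogen.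

Among the compounds with values here, two measured steps concern this same place: a 17-fold lower number from compound 1 to compound 3 (1.22 log units; beyond the scatter) and a 79-fold lower number from compound 2 to compound 3 (1.90 log units; beyond the scatter) are both large. A third, a 4.7-fold higher number from compound 1 to compound 2 (0.67 log units; beyond the scatter), is modest and shows that a single hydroxy on the group at this place also moves the number. Within the data shown here, none of the three compounds carries a pyridin-4-yl group, so no measured step covers this replacement directly. Going by the two large steps, the group on this nitrogen matters in this assay and a move away from 3-fluorophenyl is expected to give a higher number, though the size is poorly defined. The expected change is a 5.5-fold higher number from compound 3 to compound 4 (0.74 log units; beyond the scatter) on this reasoning. Compound 4 is estimated at 400 nM (expected range 80 nM to 2500 nM).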

Compound 4, half-maximal inhibitory concentration: 2520 nM
Estimate against measurement, compound 4: 6.3-fold (0.80 log units) below; the whole stated range lies below it.
By their numbers in this assay, from the lowest: compound 3; then compound 1; then compound 4; then compound 2.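

In this assay the 3-fluorophenyl group proves hard to replace even with another six-membered aromatic ring of nearly the same size, with a 35-fold higher number from compound 3 to compound 4 (1.54 log units; beyond the scatter) as the large step at this aromatic nitrogen. Pyridin-4-yl instead falls among the two oxygen-bearing groups, with a 2.3-fold lower number from compound 2 to compound 4 (0.36 log units; beyond the scatter) on one side and a 2.1-fold higher number from compound 1 to compound 4 (0.32 log units; beyond the scatter) on the other, both modest though beyond the scatter. Among the four compounds, the low number therefore belongs to compound 3 alone, and the hydrogen-bond acceptor in the ring of compound 4 does not bring the number back towards it.

Still open, on these data alone, is whether the low number of compound 3 depends on the fluorine itself, on its place on the ring or simply on an all-carbon ring, a question that a plain phenyl, 3-chlorophenyl or 3-aminophenyl group at this nitrogen would address. No accompanying data bear on what lies behind these differences.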